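The compounds below may be only part of what the source reports. "The series", "measured", "known", "first", "only" and "open" are said of these compounds alone.

Compound 2, `COc1ccc(OC(=O)c2nc(C)c(C)nc2C)c(/C=C/C(=O)O)c1`, was examined in a functional assay on EA.hy 926 cells (Homo sapiens) for cytotoxicity, read by MTT assay, with stated times of 24 h and 12 h, tested at 25 uM (on this read-out higher numbers stand for a stronger effect at the one concentration tested and lower numbers for a weaker effect), where it gives 45%. Among the three measured compounds this is the lowest number. Its nearest neighbour is compound 1, `Cc1nc(C)c(C(=O)Oc2ccccc2/C=C/C(=O)O)nc1C`, which in this assay gives 61.8%; the two differ only by a methoxy group in place of hydrogen on an aromatic carbon, and that step reads a number 16.8 percentage points lower from compound 1 to compound 2 (beyond the scatter). For the measured compounds named here, the furthest is compound 3, `CCOC(=O)/C=C/c1ccc(OC(=O)c2nc(C)c(C)nc2C)c(O)c1`, which in this assay gives 207%, a value far above the other two, though no single-point step links it to compound 2.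

The next compound, compound 4, is `CCOC(=O)/C=C/c1cc(OC)ccc1OC(=O)c1nc(C)c(C)nc1C`. It differs from compound 2 by ethyl in place of hydrogen on an oxygen next to a carbonyl group. Going by the values given here, no measured pair isolates this change: the only quantified step, the methoxy addition, concerns a different part of the molecule. Compound 3 also carries an ethoxycarbonyl group and shows the highest number, but it differs from compound 2 in more than one place, so it offers only a loose hint upward.

On that basis, compound 4 is expected to move upward by roughly a number 25 percentage points higher from compound 2 to compound 4 (beyond the scatter), with considerable uncertainty. The estimate for compound 4 in this assay is 70%, within a range from 30% to 140%.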

Compound 4, a percentage reported as activity, at one concentration (the size of the read-out at that concentration, not a potency): 23.4%
Estimate against measurement, compound 4: 46.6 percentage points above; measured number below the stated range.
By their numbers in this assay, from the lowest: compound 4; then compound 2; then compound 1; then compound 3.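

For the compounds shown here, replacing the hydrogen of the carboxy group with ethyl, which turns 2-carboxyethenyl into 2-(ethoxycarbonyl)ethenyl, gives the first one-place reading of this change in this assay: a number 21.6 percentage points lower from compound 2 to compound 4 (beyond the scatter). Going by these compounds alone, the direction is downward, which the earlier compounds could not show, since compound 3 also carries an ethoxycarbonyl group but differs from compound 2 in more than one place. The step therefore ties the ester to a lower number on this methoxy-bearing compound, and nothing among the data shown accounts for that drop.

The compounds shown leave open whether ethyl at this oxygen would read the same way on the core of compound 1, which has hydrogen where compound 2 has methoxy, and whether a methyl ester, a longer chain on that oxygen or an amide in place of the ester would stay close to compound 4 or to compound 2. With each compound read at a single concentration, they also leave open how these numbers would run across a range of concentrations.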